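This account rests on a few compounds, and the source may have more. Where it says the series, first, only, none or still open, it means among the compounds named here.

Compound 1 `CCOC(=O)c1cc(-c2cccc(OCc3ccccc3)c2)on1` — in an ADME assay on Vero cells (Chlorocebus sabaeus) for cytotoxicity, with a stated time of 72 h (on this read-out higher numbers stand for weaker inhibition and lower numbers for stronger inhibition), compound 1 gives > 128000 nM.
Compound 2 `CCOC(=O)c1cc(-c2cccc(OCc3cccc(Cl)c3)c2)on1` — in this assay compound 2 gives > 128000 nM.
Compound 3 `CCOC(=O)c1cc(-c2cccc(OCc3cccc(Br)c3)c2)on1` — in this assay compound 3 gives > 128000 nM.

For compound 1 this value is a limit of this assay, not a measured number. The same holds for compound 2, whose value is a limit. For compound 3 the value is likewise a limit. All three sit at the same place, as summarised by the limit of > 128000 nM in this assay, at which 3 of the 3 values shown sit.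

Compound 4 `CCOC(=O)c1cc(-c2cccc(OCc3cccc(OC(F)(F)F)c3)c2)on1` differs from compound 1 in one place: trifluoromethoxy in place of hydrogen on an aromatic carbon. The measured steps closest to this change are a step that the two limits leave unreadable from compound 1 to compound 2 and a step that the two limits leave unreadable from compound 1 to compound 3; both put a halogen where compound 1 carries hydrogen, and in both the two limits hide how large the step is. The third step, a step that the two limits leave unreadable from compound 2 to compound 3, is unreadable for the same reason.

For the measured compounds named here, with every step so far ending at the limit, the expectation for compound 4 is that this assay will again stop at its limit. Compound 4 is therefore estimated at 200000 nM, within 128000 nM to 500000 nM. The step from compound 1 that this estimate means is expected to be a step that the limit leaves unreadable from compound 1 to compound 4.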

Compound 4, half-maximal inhibitory concentration: 101000 nM
Beside the measured number, compound 4's estimate is 2.0-fold (0.30 log units) above it; measured number outside the range, below it.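

For the compounds shown here, at this place on the ring, trifluoromethoxy gives the first actual number in this assay, whereas the other compounds stop at a limit: the limit of > 128000 nM in this assay, at which 3 of the 4 values shown sit. Trifluoromethoxy in place of hydrogen gives an at least 1.2-fold lower number from compound 1 to compound 4 (0.10 log units; that floor lies within the scatter), in place of chloro it gives an at least 1.2-fold lower number from compound 2 to compound 4 (0.10 log units; that floor lies within the scatter), and in place of bromo it gives an at least 1.2-fold lower number from compound 3 to compound 4 (0.10 log units; that floor lies within the scatter). Each of these is only a floor, so a real difference from the other three compounds is not established, and the steps among those three cannot be read.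

The compounds shown leave open how far compound 1, compound 2 and compound 3 truly lie from the limit. They also leave open whether another group at this place, such as an amine or a carboxylic acid, would give a measurable number too.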